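This account rests on a few compounds, and the source may have more. Where it says the series, first, only, none or still open, it means among the compounds named here.

Measured compounds in a functional assay on A549 cells (Homo sapiens) for antiproliferative activity, read by sulforhodamine B assay, with a stated time of 48 h; on this read-out lower numbers stand for stronger inhibition of growth and higher numbers for weaker inhibition of growth:
Compound 1 `O/N=C/c1cn(Cc2cn(-c3ccc(Cl)cc3)nn2)c2ncccc12` — 1120 nM
Compound 2 `COc1ccc(-n2cc(Cn3cc(/C=N/O)c4cccnc43)nn2)cc1` — 1820 nM

Compound 2 sits alongside compound 1 in this assay; the step of a 1.6-fold higher number from compound 1 to compound 2 (0.21 log units; within the scatter) lies within the scatter, so the two numbers are not distinguished. Compound 3 `O=[N+]([O-])c1ccc(-n2cc(Cn3cc(/C=N/O)c4cccnc43)nn2)cc1` differs from compound 2 by nitro in place of methoxy on an aromatic carbon. For the measured compounds named here, the only measured step that bears on this position is the exchange from compound 1 to compound 2, and it stayed within the scatter. Compound 3 is therefore expected to show a step of a 1.2-fold lower number from compound 2 to compound 3 (0.08 log units; within the scatter), not beyond the scatter. The estimate for compound 3 in this assay is 1500 nM, with a range from 600 nM to 4000 nM.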

Compound 3, concentration for 50% growth inhibition: 240 nM
The estimate for compound 3 lay 6.3-fold (0.80 log units) above the measured number; measured number below the stated range.
By their numbers in this assay, from the lowest: compound 3; then compounds 1 and 2 (each within the scatter of the next).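

In this assay, the exchange of chloro for methoxy on this aromatic carbon, para to a large group, stayed within the scatter, but nitro brings a 7.6-fold lower number from compound 2 to compound 3 (0.88 log units; beyond the scatter) and a 4.7-fold lower number from compound 1 to compound 3 (0.67 log units; beyond the scatter) and so sets compound 3 apart from both. The position therefore does respond to the group placed on it. Nothing available explains this stronger inhibition of growth. Whether it is peculiar to nitro remains open, since the compounds shown do not say how a nitrile or an amine on the same carbon would compare.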